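Moving the Alkoxy Group on the Amide Aryl Ring

The compounds below may be only part of what the source reports. "The series", "measured", "known", "first", "only" and "open" are said of these compounds alone.

Compound 1, `COc1ccc2c(=O)c(/C=C/C(=O)NCc3ccccc3)coc2c1`, in a functional assay (QGY7701 cells, Homo sapiens) for inhibition, read by MTT assay, with a stated time of 48 h (on this read-out lower numbers stand for stronger inhibition and higher numbers for weaker inhibition), gives > 100000 nM, which is a limit of the assay and not a number.
Compound 2, `COc1ccc2c(=O)c(/C=C/C(=O)Nc3cc(C)ccc3C)coc2c1`, in this assay gives > 100000 nM, likewise a limit of the assay.
Compound 3, `COc1ccc2c(=O)c(/C=C/C(=O)Nc3ccccc3OC)coc2c1`, in this assay gives 17600 nM.

Compound 3 is thus the only one of the three with a readable number; the other two sit at the limit of > 100000 nM in this assay, at which 2 of the 3 values shown sit. Compound 4, `CCOc1ccc(NC(=O)/C=C/c2coc3cc(OC)ccc3c2=O)cc1`, is not yet measured. It differs from compound 3 in one place: 4-ethoxyphenyl in place of 2-methoxyphenyl on an amide-type nitrogen.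

Going by the values given here, two measured steps bear on the aryl group on the amide nitrogen. Replacing benzyl by 2-methoxyphenyl gave an at least 5.6-fold lower number from compound 1 to compound 3 (0.75 log units; beyond the scatter), and replacing 2,5-dimethylphenyl by 2-methoxyphenyl gave an at least 5.6-fold lower number from compound 2 to compound 3 (0.75 log units; beyond the scatter). Among the compounds with values here, both steps point to the 2-methoxyphenyl group as the source of the only readable number, but neither tests a 4-ethoxyphenyl group, so the size of the new step cannot be read from them directly. Compound 2 carries a phenyl without a methoxy group and sits at the limit. Since compound 4 gives up the 2-methoxyphenyl group, it is expected to give a higher number than compound 3, an estimated step of a 2.6-fold higher number from compound 3 to compound 4 (0.41 log units; beyond the scatter), with a real chance of a limit. The estimate for compound 4 in this assay is 45000 nM, with a range from 12000 nM to 150000 nM.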

Compound 4, half-maximal inhibitory concentration: > 100000 nM
Compound 4: only a limit was reported; the forecaster's own chance of this, stated with the estimate: 40%; at least 2.2-fold (0.34 log units) between middle value and limit.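

In this assay, putting 4-ethoxyphenyl in place of 2-methoxyphenyl on the amide-type nitrogen gives an at least 5.6-fold higher number from compound 3 to compound 4 (0.75 log units; beyond the scatter). This is the first compound shown with a different alkoxy-bearing phenyl group, and it shows that having an alkoxy group on the phenyl ring does not by itself give a readable number, since the 2-methoxyphenyl group of compound 3 is not matched by the 4-ethoxyphenyl group of compound 4. Compound 3 alone now stands clear of the limit: the limit of > 100000 nM in this assay, at which 3 of the 4 values shown sit.

The steps from compound 1 and compound 2 to compound 4 join two limits and cannot be read, so no order can be given among these three compounds. This swap also changes both the alkoxy group's place on the ring and its chain, from methoxy to ethoxy, and the compounds shown do not separate these two changes or tell whether a hydroxy group or an amine in place of the methoxy group of compound 3 would keep a readable number.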